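Chloro on the benzylamide of compound 2

A few compounds are considered here, and "the series" means these few. Any claim that something is new, unique, unknown or untested is made for them only; others in the source may bear on it.

Within the data shown here, compound 2 `COc1ccccc1C(=O)Nc1ccc2nc(SCC(=O)NCc3ccccc3)sc2c1` supplies the only number so far: in a functional assay on MCF7 cells (Homo sapiens) for cytotoxicity, read by MTT assay, with a stated time of 48 h (on this read-out lower numbers stand for stronger inhibition and higher numbers for weaker inhibition), compound 2 gives 17200 nM. Compound 1 `O=C(CSc1nc2ccc(NC(=O)c3ccc([N+](=O)[O-])cc3)cc2s1)NCc1ccc(Cl)cc1` returns a limit rather than a number, > 100000 nM, which is the limit of > 100000 nM in this assay, at which 1 of the 2 values shown sits. Compound 3 `COc1ccccc1C(=O)Nc1ccc2nc(SCC(=O)NCc3ccc(Cl)cc3)sc2c1` differs from compound 2 by chloro in place of hydrogen on an aromatic carbon. Among the measured compounds shown here, no measured step of this kind exists in the set, so the change from compound 2 to compound 3 in this assay is expected to stay within the scatter, with no clear direction. Compound 3 is estimated at 20000 nM, within 6000 nM to 70000 nM, which means an expected step of a 1.2-fold higher number from compound 2 to compound 3 (0.07 log units; within the scatter).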

Compound 3, half-maximal inhibitory concentration: 1100 nM
Estimate against measurement, compound 3: 18-fold (1.26 log units) above; the measured number lies below the stated range.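

In this assay, the benzyl end of the series is sensitive at the place para to a large group: phenyl to 4-chlorophenyl gives a 16-fold lower number from compound 2 to compound 3 (1.19 log units; beyond the scatter). With 4-chlorobenzyl held constant, the group on the carbonyl carbon also matters, as 2-methoxyphenyl in place of 4-nitrophenyl gives an at least 90-fold lower number from compound 1 to compound 3 (1.95 log units; beyond the scatter). Compound 1 stands at a limit, so this second step is a bound and not a measured size: the limit of > 100000 nM in this assay, at which 1 of the 3 values shown sits.

The compounds shown leave open whether fluoro, bromo or methyl at the same place would match chloro. Also open, as far as these compounds go, is whether chloro at another place on that ring would keep the step.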